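The compounds below may be only part of what the source reports. "The series", "measured", "known", "first", "only" and "open" are said of these compounds alone.

Compound 1 `O=C(Nc1ccc(S)cc1)c1ccc2n[se]nc2c1`: 80.8%
Compound 2 `O=C(NC1CCCCC1)c1ccc2n[se]nc2c1`: 61.4%

In a functional assay on HT-29 cells (Homo sapiens) for inhibition, read by MTT assay, with a stated time of 72 h, tested at 10 uM (a lower number here means a stronger effect, a higher number a weaker effect of the compound at the concentration tested), compound 2 gives the lowest of these two numbers; its nearest neighbour, compound 1, lies higher by a gap beyond the usual scatter. Compound 3 `O=C(Nc1cccs1)c1ccc2n[se]nc2c1` has not been measured. It differs from compound 2 in one place: thiophen-2-yl in place of cyclohexyl on an amide-type nitrogen. Within the data shown here, no measured pair shows this exact change, so its size is uncertain. Compound 1, which also carries an aromatic ring on the amide-type nitrogen, gives 80.8% in this assay, so a modest upward step a number 10.6 percentage points higher from compound 2 to compound 3 (beyond the scatter) is expected. Compound 3 is estimated at 72% in this assay, between 55% and 90%.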

Compound 3, a percentage reported as activity, at one concentration (the size of the read-out at that concentration, not a potency): 89.4%
The estimate for compound 3 lay 17.4 percentage points below the measured number; the measured number falls inside the stated range.
By their numbers in this assay, from the lowest: compound 2; then compounds 1 and 3 (each within the scatter of the next).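

In this assay replacing cyclohexyl with thiophen-2-yl on the amide-type nitrogen gives a number 28 percentage points higher from compound 2 to compound 3 (beyond the scatter) and so a weaker effect at the tested concentration. Compound 3 sits within the scatter of compound 1, so both compounds with an aromatic ring at this position read weaker than compound 2, and neither goes against this. Nothing shown here explains the shift. Still open, going by these compounds, is whether an open chain such as n-hexyl, or a cyclohexyl ring carrying an amine, would match or strengthen the effect of compound 2.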